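The source may hold more compounds than are shown below. What is called first, only, known or untested is meant among the compounds shown, and "the series" means these compounds.

Three compounds share one core and differ only in the group attached to a saturated ring carbon of that core. Compound 1 `Cc1nn(-c2ncnc3nc[nH]c23)c2c1C(OCC(=O)c1ccc(F)cc1)CC(=O)N2` carries a (4-fluorophenyl)carbonyl group there, and in a functional assay on HEK293 cells for agonist activity at G-protein coupled receptor 39 (Homo sapiens), read by scintillation proximity assay and inositol phosphate accumulation, with a stated time of 75 min, in the presence of a further agent that is not named here (on this read-out lower numbers stand for an effect already at smaller amounts and higher numbers for an effect only at larger amounts of compound), compound 1 gives 3 nM. Compound 2 `Cc1nn(-c2ncnc3nc[nH]c23)c2c1C(OCc1ccccc1C#N)CC(=O)N2` carries a 2-cyanophenyl group instead, and in this assay compound 2 gives 8 nM. Compound 3 `Cc1nn(-c2ncnc3nc[nH]c23)c2c1C(OCc1ccc(C(C)C)cc1)CC(=O)N2` carries a 4-isopropylphenyl group, and in this assay compound 3 gives 5 nM. Compound 2 stands at the highest of the three numbers, but the gap a 1.6-fold lower number from compound 2 to compound 3 (0.20 log units; within the scatter) is within the scatter, while only a 2.7-fold higher number from compound 1 to compound 2 (0.43 log units; beyond the scatter) lies beyond it; the remaining step, a 1.7-fold higher number from compound 1 to compound 3 (0.22 log units; within the scatter), is also within the scatter.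

Compound 4 `Cc1nn(-c2ncnc3nc[nH]c23)c2c1C(NC(=O)Cc1cccs1)CC(=O)N2` has not yet been measured. The change is (((thiophen-2-yl)methyl)carbonyl)amino in place of (2-cyanobenzyl)oxy on a saturated ring carbon. The three measured steps all swap one aromatic group for another while keeping the oxygen link, and none exchanges that link for a nitrogen-bound carbonyl, so they bear on this change only loosely. What they do show is that varied aromatic groups on this position give numbers close together, the largest step being a 2.7-fold higher number from compound 1 to compound 2 (0.43 log units; beyond the scatter). A step of modest size, in either direction, is therefore the most that is expected. For compound 4 in this assay the expected value is 15 nM, between 4 nM and 60 nM, which means an expected step of a 1.9-fold higher number from compound 2 to compound 4 (0.27 log units; within the scatter).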

Compound 4, half-maximal effective concentration: 3 nM
Estimate against measurement, compound 4: 5.0-fold (0.70 log units) above, and the stated range ends above it.
By their numbers in this assay, from the lowest: compounds 1, 4, 3 and 2 (each within the scatter of the next, the first and the last beyond it).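

Among these compounds, the link at this position can change without loss: in this assay, (((thiophen-2-yl)methyl)carbonyl)amino in place of (2-cyanobenzyl)oxy gives a 2.7-fold lower number from compound 2 to compound 4 (0.43 log units; beyond the scatter), so a low number on this saturated ring carbon does not depend on the oxygen link held by all the earlier compounds. This step also changes several things at once, as the entering group brings an amide nitrogen with its hydrogen, a carbonyl and a five-membered aromatic ring with a sulfur atom, while the six-membered ring and the nitrile leave, and the single step cannot be divided among these parts. Nothing measured here explains the step.

Still open, as far as these compounds go, is which part of the change carries the step: a phenyl ring on the same amide link, or a thiophene ring on the oxygen link, would begin to separate the contributions. Also open, from the compounds shown here alone, is how this position responds to a free amine, a carboxylic acid, or a longer chain carrying the thiophene ring.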